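A larger hydrazone on the amine nitrogen of compound 2

The source may hold more compounds than are shown below. What is called first, only, known or untested is meant among the compounds shown, and "the series" means these compounds.

The series shares one core, varied only on an amine nitrogen. Compound 1 `CCOC(=O)C1=C(N/N=C(\c2ccc([N+](=O)[O-])cc2)N2CCN(c3ccc(F)cc3)CC2)Nc2[nH]nc(C)c2C1c1ccc(N(C)C)cc1` carries the largest group there and in a functional assay on HeLa cells (Homo sapiens) for inhibition, read by MTT assay, with a stated time of 48 h (a lower number here means a stronger inhibitor, a higher number a weaker inhibitor), compound 1 gives 87000 nM. Compound 2 `CCOC(=O)C1=C(N/N=C(/Cl)C#N)Nc2[nH]nc(C)c2C1c1ccc(N(C)C)cc1` carries a smaller group on that nitrogen, and in this assay compound 2 gives 26200 nM, the second highest of the three numbers. Compound 3 `CCOC(=O)C1=C(N)Nc2[nH]nc(C)c2C1c1ccc(N(C)C)cc1` bears only a hydrogen on that nitrogen, and in this assay compound 3 gives 6220 nM.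

Within the data shown here, the one step that can be read directly, a 4.2-fold lower number from compound 2 to compound 3 (0.62 log units; beyond the scatter), shows that removing the group from the amine nitrogen lowers the number. Between compound 2 and compound 1, the two values show that the larger group goes with the higher number.

Compound 4 `CCOC(=O)C(=NNC1=C(C(=O)OCC)C(c2ccc(N(C)C)cc2)c2c(C)n[nH]c2N1)C(=O)OCC` is not yet measured. Relative to compound 2 the change is a group of 12 heavy atoms (7 carbon, 1 nitrogen, 4 oxygen; no ring) in place of a group of 5 heavy atoms (2 carbon, 2 nitrogen, 1 chlorine; no ring), on an amine nitrogen. The group that enters is larger than the one that leaves, and the step from compound 2 to compound 3 went the other way when the group was taken off. On that basis compound 4 is expected to give a somewhat higher number than compound 2, a step of about a 1.5-fold higher number from compound 2 to compound 4 (0.18 log units; within the scatter). The estimate for compound 4 in this assay is 40000 nM, with a range from 15000 nM to 110000 nM.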

Compound 4, half-maximal inhibitory concentration: 83800 nM
Compound 4: middle estimate off by 2.1-fold (0.32 log units), on the low side; the measured number falls inside the stated range.
By their numbers in this assay, from the lowest: compound 3; then compound 2; then compounds 4 and 1 (each within the scatter of the next).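

In this assay the exchange on the amine nitrogen gives a 3.2-fold higher number from compound 2 to compound 4 (0.50 log units; beyond the scatter) and so extends the rise seen with the larger group of compound 1 to a group with no ring, while putting this group in place of the hydrogen gives a 13-fold higher number from compound 3 to compound 4 (1.13 log units; beyond the scatter) as the largest step read here. Compound 4 gives 83800 nM and compound 1 gives 87000 nM as values within the scatter of each other, so a ring in the group is not needed to reach that level, and among these compounds a still larger group with rings brings no further rise. No measurement shown explains why these groups raise the number, and the step can be described only as a change in the values.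

The compounds shown leave open where between the hydrogen of compound 3 and the groups of compounds 2 and 4 a small group such as methyl or acetyl on this nitrogen would fall. They also leave open whether a carboxylic acid or an amine within the entering group would keep the number at the level of compound 4 or bring it closer to that of compound 3.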